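Phenyl in place of neopentyl: notes on unbound fraction

The compounds below may be only part of what the source reports. "The series", "measured", "known", "first", "only" and "open" are said of these compounds alone.

Measured in an ADME assay on the whole organism (plasma, Mus musculus, strain CD-1) for protein binding, read by LC-MS, with a stated time of 24 h; on this read-out lower numbers stand for a smaller free fraction and higher numbers for a larger free fraction:
- compound 1 `Cc1noc(-c2ccc(O[C@H]3CCC[C@H](C(=O)O)C3)cc2)c1COC(=O)N(C)CCC(C)C` gives 0.004
- compound 2 `Cc1noc(-c2ccc(O[C@H]3CCC[C@H](C(=O)O)C3)cc2)c1CNC(=O)OCCC(C)(C)C` gives 0.004
- compound 3 `Cc1nc(-c2nnn(C)c2COC(=O)N(C)CC2CCC2)ccc1O[C@H]1CCC[C@H](C(=O)O)C1` gives 0.1

In this assay compound 2 stands level with compound 1, and these two share the lowest number of the three. Compound 3 stands clearly higher, at 0.1. The next change leads to compound 4 `Cc1noc(-c2ccc(O[C@H]3CCC[C@H](C(=O)O)C3)cc2)c1CNC(=O)OCc1ccccc1`, which is not yet measured: phenyl in place of neopentyl on a saturated chain carbon bound to an oxygen next to a carbonyl group. In words, phenyl replaces neopentyl on a saturated chain carbon bound to an oxygen next to a carbonyl group. Among the measured compounds shown here, only one measured step bears on this: no change at the digits printed from compound 1 to compound 2 (within the scatter). For the measured compounds named here, no measured pair carries this exact change, and compound 3 differs from compound 2 in more than one place, so it gives no guide to its size. With compound 2 as the base and the step to it from compound 1 flat, no shift beyond the scatter is expected. The estimated step is a 1.3-fold higher number from compound 2 to compound 4 (0.10 log units; within the scatter). For compound 4 the expected value is 0.005, with an estimated range of 0.0025 to 0.01.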

Compound 4, unbound fraction: 0.007
The estimate for compound 4 lay 1.4-fold (0.15 log units) below the measured number; the range from low to high includes it.
By their numbers in this assay, from the lowest: compounds 1, 2 and 4 (each within the scatter of the next); then compound 3.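

In this assay, phenyl in place of neopentyl on a saturated chain carbon bound to an oxygen next to a carbonyl group gives a 1.8-fold higher number from compound 2 to compound 4 (0.24 log units; within the scatter), so an aromatic ring at this position reads the same as the branched chain. The larger exchange of the whole group gives a 1.8-fold higher number from compound 1 to compound 4 (0.24 log units; within the scatter), so compound 4 joins the other two in a single band of the unbound fraction, whichever of these three side chains is present. No measured property in hand accounts for this flat result.

Open, on these data alone, is whether pyridyl in place of phenyl, or an amine or hydroxyl on this chain, would shift the number in this assay. Compound 3, at 0.1, differs in more than one place, so which of its differences goes with that value remains unresolved.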